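This account rests on a few compounds, and the source may have more. Where it says the series, first, only, none or still open, it means among the compounds named here.

In an ADME assay on Karpas-1106P cells (Homo sapiens) for cytotoxicity (a lower number here means that less compound is needed, a higher number that more compound is needed for the effect), two compounds built on one shared core have been measured so far. Compound 1 (`Cc1ccc(S(=O)(=O)N[C@@H](CC(=O)NC(C)(C)C)C(=O)NCCNC(=O)c2cccc(O)c2)cc1`) gives > 11100 nM, which is a limit of the assay and not a number. Compound 2 (`Cc1ccc(S(=O)(=O)N[C@@H](CC(=O)NC(C)(C)C)C(=O)NCCNC(=O)c2ccc(Cl)cc2)cc1`) gives > 11100 nM, which is also a limit, so its true position on the scale cannot be read. Compound 3 (`Cc1ccc(S(=O)(=O)N[C@@H](CC(=O)NC(C)(C)C)C(=O)NCCNC(=O)c2cc(C)ccc2F)cc1`) keeps that core and changes a single group, with 2-fluoro-5-methylphenyl in place of 4-chlorophenyl on a carbonyl carbon.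

Going by the values given here, the one measured step at this place is a step that the two limits leave unreadable from compound 1 to compound 2, so it offers no size to carry forward. The wider picture is just as sparse: the limit of > 11100 nM in this assay, at which 2 of the 2 values shown sit. No step beyond the scatter can therefore be forecast, and another limit is the likeliest result. This expectation leans on compound 2, whose > 11100 nM is a limit. The expected change is a step that the limit leaves unreadable from compound 2 to compound 3, and this is only an estimate. The estimated value for compound 3 is 14000 nM, with an expected range from 7000 nM to 30000 nM.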

Compound 3, half-maximal effective concentration: > 11100 nM
Compound 3: a limit, no number; the forecaster's own chance of this, stated with the estimate: 85%; the middle value lies beyond the limit too.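

In this assay compound 3 gives > 11100 nM, which is a limit and not a number. No step among compound 1, compound 2 and compound 3 can be read, because all three stop at the same limit: the limit of > 11100 nM in this assay, at which 3 of the 3 values shown sit.

The compounds shown leave open how far each true value lies beyond that limit, and whether any change on the shared core would give a readable number.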